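Swapping a Dichlorinated Ring for a Single Chlorine

The source may hold more compounds than are shown below. What is called first, only, known or untested is meant among the compounds shown, and "the series" means these compounds.

Measured so far:
compound 1, `COC(=O)/C=C/c1cccc(N(Cc2ccc(/C=C/c3ccccn3)cc2)C(=O)C2CCCCC2)c1`: 309 nM
compound 2, `COC(=O)/C=C/c1cccc(N(Cc2ccc(/C=C/c3c(Cl)cccc3Cl)cc2)C(=O)C2CCCCC2)c1`: 150 nM

Both compounds were tested in an assay on isolated protein with Bile acid receptor (Homo sapiens) as the target; a higher number here means that more compound is needed for the effect, a lower number that less compound is needed. Compound 1 gives 309 nM and compound 2 gives 150 nM. For the measured compounds named here, of these two numbers, compound 2 has the lower one; the only step known so far, a 2.1-fold lower number from compound 1 to compound 2 (0.31 log units; beyond the scatter), is modest but beyond the usual scatter.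

Compound 3, `COC(=O)/C=C/c1cccc(N(Cc2ccc(/C=C/c3cccc(Cl)c3)cc2)C(=O)C2CCCCC2)c1`, has not yet been measured in this assay. It differs from compound 2 in one place: 3-chlorophenyl in place of 2,6-dichlorophenyl on a double-bonded chain carbon bound to a double-bonded chain carbon. Going by the values given here, no measured pair shows this particular change, so the single known step is only a loose guide. That step shows that the group on this double-bonded chain carbon can move the number by a modest amount, and the ring of compound 3 keeps one chlorine but loses the other. A small shift is therefore expected, most likely toward a somewhat higher number, with a real chance that it stays within the scatter.

Compound 3 is expected to give about 250 nM in this assay, within a range from 100 nM to 700 nM. This corresponds to an expected step of a 1.7-fold higher number from compound 2 to compound 3 (0.22 log units; within the scatter).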

Compound 3, half-maximal effective concentration: 165 nM
Compound 3: the middle estimate sits 1.5-fold (0.18 log units) above what was measured; measured number inside the range.
By their numbers in this assay, from the lowest: compounds 2, 3 and 1 (each within the scatter of the next, the first and the last beyond it).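

In this assay, the change from 2,6-dichlorophenyl to 3-chlorophenyl gives a 1.1-fold higher number from compound 2 to compound 3 (0.04 log units; within the scatter) and so leaves the two compounds indistinguishable: on this double-bonded chain carbon, the ring does not need two chlorines to give a number in this range. For the compounds shown here, the comparison with the pyridin-2-yl ring is less clear-cut than the earlier step suggested, since 3-chlorophenyl in its place gives a 1.9-fold lower number from compound 1 to compound 3 (0.27 log units; within the scatter) and compound 3 therefore cannot be separated from either of the other two compounds, even though a 2.1-fold lower number from compound 1 to compound 2 (0.31 log units; beyond the scatter) remains the one step here beyond the scatter. The data offer no explanation for why these three rings give such closely spaced numbers.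

The compounds shown leave open whether any chlorine is needed at all, since a plain phenyl ring with no chlorine would be required to answer that. They also leave open whether a ring carrying a different kind of group, such as a methoxy group, an amine or a carboxylic acid, would move the number well beyond the narrow band seen so far.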